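The compounds below may be only part of what the source reports. "The series", "measured", "known", "first", "only" and "open" are said of these compounds alone.

Compound 2 `CC1CC/C(=N\Nc2cccc(Cl)c2)c2ncc(C(=O)O)c(=O)n21` carries a 3-chlorophenyl group on the amine nitrogen. In a functional assay on the whole organism for inhibition, with Rattus norvegicus as the target (on this read-out lower numbers stand for an effect already at smaller amounts and higher numbers for an effect only at larger amounts of compound), compound 2 gives > 100 umol/kg, which is a limit of the assay and not a number. Compound 1 `CCOC(=O)c1cnc2n(c1=O)C(C)CC/C2=N\Nc1ccccc1` likewise reaches only a limit in this assay, > 1000 umol/kg. Compound 3 `CC1CC/C(=N\Nc2ccc(O)cc2)c2ncc(C(=O)O)c(=O)n21` differs from compound 2 by 4-hydroxyphenyl in place of 3-chlorophenyl on an amine nitrogen. Among the compounds with values here, no step between measured compounds is available here, so compound 3 is expected to stay close to compound 2, with an expected step that the limit leaves unreadable from compound 2 to compound 3, none beyond the scatter. Compound 3 is therefore estimated at 300 umol/kg, with a range from 100 umol/kg to 1000 umol/kg.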

Compound 3, dose for 50% inhibition: > 100 umol/kg
Compound 3 was reported as a limit; the forecaster's own chance of this, stated with the estimate: 70%; the middle value does not contradict the limit.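

Compound 2 and compound 3 both reach only a limit in this assay, so no step can be read between them. The compounds shown leave open whether 4-hydroxyphenyl and 3-chlorophenyl on an amine nitrogen differ at all in this assay.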